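Hydroxy to dimethylamino on the aromatic ring of the series

A few compounds are considered here, and "the series" means these few. Any claim that something is new, unique, unknown or untested is made for them only; others in the source may bear on it.

Compound 2 `CC1=CC[C@H](C(C)(C)NC(=S)N/N=C/c2ccc(O)cc2)CC1` stands at the edge of the numbers: in a functional assay on NCI-H460 cells (Homo sapiens) for inhibition, read by sulforhodamine B assay, with a stated time of 48 h (a higher number here means a weaker inhibitor of growth, a lower number a stronger inhibitor of growth), compound 2 gives only the assay limit > 100000 nM, not a number. Its companion compound 1 `CC1=CC[C@H](C(C)(C)NC(=S)N/N=C/c2ccccc2)CC1` bears hydrogen where compound 2 bears hydroxy. In this assay compound 1 gives 53900 nM. For the measured compounds named here, the single measured step, an at least 1.8-fold higher number from compound 1 to compound 2 (0.26 log units; that floor lies within the scatter), is the only guide so far, and its floor sits within the scatter, as does the limit itself (the limit of > 100000 nM in this assay, at which 1 of the 2 values shown sits).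

Compound 3 `CC1=CC[C@H](C(C)(C)NC(=S)N/N=C/c2ccc(N(C)C)cc2)CC1` differs from compound 2 by dimethylamino in place of hydroxy on an aromatic carbon. Going by the values given here, no measured step touches dimethylamino; the hydroxy-against-hydrogen step does not carry over to this change, so no direction beyond the scatter can be read from it, and the step of an at least 1.6-fold lower number from compound 2 to compound 3 (0.22 log units; that floor lies within the scatter) is expected to be small. Compound 3 is therefore estimated at 60000 nM in this assay, within a range from 20000 nM to 200000 nM.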

Compound 3, concentration for total growth inhibition: > 100000 nM
Compound 3 gave a limit, no number (the forecaster's own chance of this, stated with the estimate: 35%); middle value at least 1.6-fold (0.22 log units) from the limit.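

In this assay compound 3 gives > 100000 nM, a limit of the assay and not a number. Dimethylamino in place of hydrogen on this aromatic carbon gives an at least 1.8-fold higher number from compound 1 to compound 3 (0.26 log units; that floor lies within the scatter), so neither this larger group without a hydrogen-bond donor nor hydroxy is shown to move the result beyond the scatter. The step between compound 2 and compound 3 cannot be read, and a second group at this place now ends at the limit: the limit of > 100000 nM in this assay, at which 2 of the 3 values shown sit.

On these data alone, whether methoxy or chloro on this aromatic carbon would give a number rather than a limit stays open. Compound 1, at 53900 nM, holds the only number among the compounds shown, so no ordering of groups at this place can yet be read.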